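A few compounds are considered here, and "the series" means these few. Any claim that something is new, unique, unknown or untested is made for them only; others in the source may bear on it.

Compound 1 `O=c1c(-c2cccc([N+](=O)[O-])c2)nc2ccccc2n1Cc1ccccc1` gives 9 nM in an assay on cells for activation of Cystic fibrosis transmembrane conductance regulator (Homo sapiens), read by fluorescence, with a stated time of 10 min (a higher number here means that more compound is needed for the effect, a lower number that less compound is needed), the lowest number of the three measured. Compound 3 `O=c1c(-c2cccc([N+](=O)[O-])c2)nc2ccccc2n1Cc1ccco1` gives 20 nM, a step of a 2.2-fold higher number from compound 1 to compound 3 (0.35 log units; beyond the scatter). Compound 2 `N#Cc1cccc(-c2nc3ccccc3n(Cc3ccccc3)c2=O)c1` gives 1000 nM, a step of a 110-fold higher number from compound 1 to compound 2 (2.05 log units; beyond the scatter). Compound 4 `Nc1ccc([N+](=O)[O-])cc1-c1nc2ccccc2n(Cc2ccccc2)c1=O` differs from compound 1 by amino in place of hydrogen on an aromatic carbon. Among the compounds with values here, no measured step adds a group to this ring; the only change made on it, from compound 1 to compound 2, was large, whereas the change elsewhere, from compound 1 to compound 3, was modest. A moderate shift in this assay, more likely toward a higher number, is therefore expected, with wide uncertainty. For compound 4 the estimate is 30 nM (5 nM to 200 nM). This corresponds to an expected step of a 3.3-fold higher number from compound 1 to compound 4 (0.52 log units; beyond the scatter).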

Compound 4, half-maximal effective concentration: 200 nM
Compound 4: the middle estimate sits 6.7-fold (0.82 log units) below what was measured; the range from low to high includes it.
By their numbers in this assay, from the lowest: compound 1; then compound 3; then compound 4; then compound 2.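

In this assay, amino in place of hydrogen on an aromatic carbon, ortho to a large group and para to a nitro group, gives a large step (a 22-fold higher number from compound 1 to compound 4 (1.35 log units; beyond the scatter)). The nitro group is retained here, so this ring is shown to be sensitive to an added group as well as to the swap of nitro for cyano (a 110-fold higher number from compound 1 to compound 2 (2.05 log units; beyond the scatter)). Nothing shown explains this step. From the compounds shown here alone, whether the loss is specific to amino remains open: a methyl group or a fluorine atom on the same carbon would separate the two readings.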